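Swapping one aromatic ring at the assay limit

The compounds below may be only part of what the source reports. "The series", "measured", "known", "first", "only" and "open" are said of these compounds alone.

- compound 1 `CSc1ccc(NC(=O)Nc2cc(C)nc3ccccc23)cc1`: 16000 nM
- compound 2 `CCc1ccc(NC(=O)Nc2cc(C)nc3ccccc23)cc1`: 17000 nM
- compound 3 `Cc1ccc(NC(=O)Nc2cc(C)nc3ccccc23)cc1`: > 25000 nM (a limit, not a number)

In an ADME assay on HepG2 cells (Homo sapiens) for cytotoxicity, with a stated time of 72 h (a higher number here means that more compound is needed for the effect, a lower number that less compound is needed), compound 3 gives > 25000 nM, which is a limit and not a measured number. For compound 3 this is the limit of > 25000 nM in this assay, at which 1 of the 3 values shown sits.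

Compound 4 `Cc1cc(NC(=O)Nc2ncccc2C)c2ccccc2n1` carries 3-methylpyridin-2-yl in place of 4-methylphenyl on an amide-type nitrogen. The entering ring holds a hetero atom, and the leaving ring holds none.

Three measured steps offer the nearest guidance, and all of them swap a small group rather than the ring itself. They are a 1.1-fold higher number from compound 1 to compound 2 (0.03 log units; within the scatter), an at least 1.5-fold higher number from compound 1 to compound 3 (0.19 log units; that floor lies within the scatter) and an at least 1.4-fold higher number from compound 2 to compound 3 (0.16 log units; that floor lies within the scatter). None of them goes beyond the scatter, and none places a hetero atom in the ring, so the data give no direct guide to this change. No step beyond the scatter is therefore expected in this assay, and no direction can be named. The estimated step is a number no higher from compound 3 to compound 4 (the limit leaves the size open). A report of only a limit would also be no surprise. Compound 4 is expected near 25000 nM, with an estimated range of 12000 nM to 45000 nM.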

Compound 4, half-maximal effective concentration: > 25000 nM
Compound 4 gave a limit, no number; the forecaster's own chance of this, stated with the estimate: 55%; the middle value lies on the limit itself.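

In this assay, compound 3 and compound 4 each give a limit and not a number, so no step between them can be read: the limit of > 25000 nM in this assay, at which 2 of the 4 values shown sit.

Whether 3-methylpyridin-2-yl in place of 4-methylphenyl on an amide-type nitrogen changes the number in this assay at all, and in which direction, stays open among the compounds shown.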